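The compounds below may be only part of what the source reports. "The series", "measured", "known", "first", "only" and "open" are said of these compounds alone.

Compound 1 `C[C@@H]1CCCN1c1[nH]c2ncnc(N)c2c1C#N` serves as the reference point of this small set. In an assay on isolated protein for inhibition of Leucine-rich repeat serine/threonine-protein kinase 2 variant G2019S (Homo sapiens), read by TR-FRET and LanthaScreen, with stated times of 50 min and 30 min, in the presence of a further agent that is not named here (a higher number here means a weaker inhibitor, a lower number a stronger inhibitor), compound 1 gives 201 nM, the lowest of the three numbers recorded. Compound 2 `Cc1cn(C)nc1Nc1cc2c(c(N)n1)c(C#N)c(N1CCC[C@H]1C)n2C` gives 1290 nM in this assay, a gap from compound 1 that lies beyond the usual scatter, and compound 3 `Cn1c(NCc2ccccc2F)c(C#N)c2c(N)ncnc21` gives 1740 nM in this assay, the furthest from compound 1. Within the data shown here, compounds 2 and 3 each differ from compound 1 in more than one place, so no single step between measured compounds can be read off.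

Compound 4 `C[C@@H]1CCCN1c1c(C#N)c2c(N)ncnc2n1C` has not yet been measured. It differs from compound 1 by one change: methyl in place of hydrogen on an aromatic nitrogen. Compound 2 and compound 3 also carry methyl on that aromatic nitrogen, but other changes accompany it in both, so their higher numbers cannot be traced to that one change alone. On this basis a modest step toward a higher number, possibly within the scatter, is expected, a 2.0-fold higher number from compound 1 to compound 4 (0.30 log units; within the scatter). Compound 4 is therefore estimated to give about 400 nM in this assay, within a range from 150 nM to 1200 nM.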

Compound 4, half-maximal inhibitory concentration: 11 nM
Beside the measured number, compound 4's estimate is 36-fold (1.56 log units) above it, outside the stated range (below it).
By their numbers in this assay, from the lowest: compound 4; then compound 1; then compounds 2 and 3 (each within the scatter of the next).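

Swapping the hydrogen on the aromatic nitrogen for methyl gives an 18-fold lower number from compound 1 to compound 4 (1.26 log units; beyond the scatter) in this assay, a large step beyond the scatter. Among these compounds, this is the first single change that can be read in the set, and it shows that this nitrogen, next to the ring atom that bears a 2-methylpyrrolidin-1-yl group, strongly affects the number, with methyl giving the stronger inhibitor of the pair. Nothing measured here accounts for the size of this step.

The compounds shown leave open whether ethyl, a longer chain or a chain ending in an amine on the same nitrogen would lower the number further or raise it again. They also leave open whether the step would be as large with a piperidine or a morpholine in place of the 2-methylpyrrolidin-1-yl group.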